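This account rests on a few compounds, and the source may have more. Where it says the series, first, only, none or still open, it means among the compounds named here.

Measured compounds:
- compound 1, `Nc1nc(O)c2c(S(=O)(=O)c3ccc4ccccc4c3)cccc2n1`: 4.85
- compound 2, `Nc1nc(N)c2c([S+]([O-])c3ccc4ccccc4c3)cccc2n1`: 4.35

In an assay for inhibition of Dihydrofolate reductase (Homo sapiens) (on this read-out higher numbers stand for higher potency (the scale is a negative logarithm) and lower numbers for lower potency), compound 1 gives 4.85, the higher of the two numbers. Compound 2, the nearest to it, sits lower by a gap beyond the usual scatter; the two differ in more than one place, so their values show only this order and nothing about either change on its own.

Compound 3, `Nc1nc(N)c2c(S(=O)(=O)c3ccc4ccccc4c3)cccc2n1`, has not yet been measured. It differs from compound 1 in one place: amino in place of hydroxy on an aromatic carbon. No step of this kind between measured compounds is available here, so the direction and size of the change cannot be taken from a shown pair. With compound 1 at 4.85 as the only anchor, the expected step is a number 0.35 log units higher from compound 1 to compound 3 (beyond the scatter), a moderate rise, though a small fall or no change beyond the scatter cannot be ruled out. Compound 3 is therefore estimated at 5.2 in this assay, within a range of 4.2 to 6.4.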

Compound 3, logarithm of the reciprocal of the active concentration, log(1/C): 4.82
The estimate for compound 3 lay 0.38 log units above the measured number; the range from low to high includes it.
By their numbers in this assay, from the lowest: compound 2; then compounds 3 and 1 (each within the scatter of the next).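

In this assay, the exchange of hydroxy for amino on this aromatic carbon, next to the ring nitrogen, comes to a number 0.03 log units lower from compound 1 to compound 3 (within the scatter), so on this read-out the two groups cannot be told apart at this position. Compound 1 and compound 2 differ in more than one place and could only give an order, whereas compound 1 and compound 3 isolate this single exchange and show that, with the rest of the structure unchanged, it leaves the number within the scatter. Nothing available here accounts for this outcome.

The compounds shown leave open whether a methoxy group, a methylamino group or a plain hydrogen on the same aromatic carbon would also stay within the scatter of compound 1 and compound 3. They also leave open whether the exchange of hydroxy for amino would give a similar step if a carboxylic acid or a longer chain stood elsewhere on the shared core.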